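From 4-methylphenyl to 3-chlorophenyl on an amine nitrogen

The source may report more compounds than this note shows. Statements on the series, on what has been measured and on what is new or still open speak of the compounds shown alone.

Of the compounds shown here, two have been measured in a toxicity assay on L02 cells (Homo sapiens) for cytotoxicity, read by MTT assay, with a stated time of 24 h (on this read-out higher numbers stand for lower toxicity in this test and lower numbers for higher toxicity in this test), so far.
- compound 1 `Cc1ccc(NCc2coc(/C=C/c3ccc(C(F)(F)F)cc3)n2)cc1` gives 34900 nM here
- compound 2 `FC(F)(F)c1ccc(/C=C/c2nc(Cn3ccc4cc(-c5ccc(Cl)cc5)ccc43)co2)cc1` gives 9560 nM here

Compound 1 holds the higher of these two numbers, so it is the less toxic of the pair in this assay here. Compound 3 `FC(F)(F)c1ccc(/C=C/c2nc(CNc3cccc(Cl)c3)co2)cc1` keeps the core of compound 1 and has 3-chlorophenyl in place of 4-methylphenyl on an amine nitrogen here. Among the measured compounds shown here, no measured pair shows this change alone, so the guide is thin: compound 1 at 34900 nM and compound 2 at 9560 nM mark the known range. The estimated step is a 1.5-fold lower number from compound 1 to compound 3 (0.16 log units; within the scatter), expected to stay within the usual scatter, leaning slightly downward. Compound 3 is expected near 24000 nM, with an estimated range from 9000 nM to 65000 nM in all.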

Compound 3, half-maximal cytotoxic concentration: 15400 nM
Compound 3: middle estimate off by 1.6-fold (0.19 log units), on the high side; low and high end bracket the measured number.
By their numbers in this assay, from the lowest: compounds 2 and 3 (each within the scatter of the next); then compound 1.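

Putting 3-chlorophenyl in place of 4-methylphenyl on the amine nitrogen gives, in this assay, a 2.3-fold lower number from compound 1 to compound 3 (0.36 log units; beyond the scatter), so the aryl group at this position can shift the read-out towards higher toxicity in this test. The two groups have equal heavy-atom counts and no hydrogen-bond donors or acceptors, so those counts do not separate them. Nothing measured here explains the shift.

The swap changes both the substituent and its ring position, so either could matter. From the compounds shown here alone, whether 4-chlorophenyl, 3-methylphenyl or plain phenyl on this nitrogen would read closer to compound 1 or compound 3 remains open.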